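The source may report more compounds than this note shows. Statements on the series, on what has been measured and on what is new or still open speak of the compounds shown alone.

Among the compounds with values here, compound 2, `COc1cc(/C=C/C(=O)/C=C(/C=C/c2ccc(OC(C)=O)c(OC)c2)NCC(C)C)ccc1OC(C)=O`, gives the higher of the two values measured so far in a functional assay on EA.hy 926 cells (Homo sapiens), read by fluorescence, tested at 10 uM; on this read-out lower numbers stand for a weaker effect and higher numbers for a stronger effect at the one concentration tested: compound 2 reaches 240%, while compound 1, `COc1cc(/C=C/C(=O)/C=C(/C=C/c2ccc(OC(C)=O)c(OC)c2)NC2CCCCC2)ccc1OC(C)=O`, reaches 113%. Within the data shown here, the single measured step, a number 127 percentage points higher from compound 1 to compound 2 (beyond the scatter), separates the two, so the isobutyl substituent on the amine nitrogen is linked to the stronger read-out within this pair. Compound 3, `CCC(C)NC(=C\C(=O)/C=C/c1ccc(OC(C)=O)c(OC)c1)/C=C/c1ccc(OC(C)=O)c(OC)c1`, has not yet been tested in this assay; it differs from compound 2 by sec-butyl in place of isobutyl on an amine nitrogen. Among the measured compounds shown here, no measured step concerns a change between two four-carbon chains on this nitrogen; the one step available, from cyclohexyl to isobutyl, removed a ring rather than rearranging a chain, so it bears on the change to compound 3 only loosely. Because compound 2 gives 240% with the isobutyl group, and the new group keeps the same atoms without a ring, compound 3 is expected to stay near it, with a step of a number 40 percentage points lower from compound 2 to compound 3 (beyond the scatter) that may fall within the scatter. The estimate for compound 3 is therefore 200%, with a range from 120% to 290%.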

Compound 3, a percentage reported as activity, at one concentration (the size of the read-out at that concentration, not a potency): 105%
Compound 3: the middle estimate sits 95 percentage points above what was measured, and the stated range ends above it.
By their numbers in this assay, from the lowest: compounds 3 and 1 (each within the scatter of the next); then compound 2.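

Within this assay, this position on the amine nitrogen proves sensitive to more than the presence of a ring: with the same atoms merely joined differently, the change from isobutyl to sec-butyl gives a number 135 percentage points lower from compound 2 to compound 3 (beyond the scatter), a step labelled large. The earlier link between losing the cyclohexyl ring and a stronger read-out therefore does not extend to every open-chain group, since sec-butyl has no ring yet gives a number 8 percentage points lower from compound 1 to compound 3 (within the scatter), leaving compound 2 as the only one of the three that stands apart, with compound 3 going against any rule based on ring removal alone. Nothing available accounts for the difference between the two butyl groups.

The compounds shown leave open whether isobutyl is a rare favourable case at this nitrogen or one member of a wider set, as a straight n-butyl chain, a tert-butyl group or a longer chain could fall with either compound 2 or compounds 1 and 3. They also leave open how a chain ending in a hydroxyl group or a carboxylic acid would behave here.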